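This account rests on a few compounds, and the source may have more. Where it says the series, first, only, none or still open, it means among the compounds named here.

For the measured compounds named here, in an ADME assay on the whole organism for inhibition, with Echinochloa crus-galli var. formosensis as the target, with a stated time of 4 days (a higher number here means a weaker inhibitor, a lower number a stronger inhibitor), compound 1 `CCN(CC)c1nc(Cl)nc(NC(C)c2ccccc2)n1` gives 1510 nM, the lowest of the three numbers so far and clearly apart from the other two. Compound 2 `CC[C@H](C)Nc1nc(Cl)nc(N[C@@H](C)c2ccccc2)n1` gives 14100 nM, and compound 3 `C[C@H](Nc1nc(Cl)nc(NC(C)(C)C)n1)c1ccccc1` gives 7410 nM.

The next compound, compound 4 `CCN(CC)c1nc(Cl)nc(N[C@H](C)c2ccccc2)n1`, keeps every atom and bond of compound 1: the two compounds have the same atoms and bonds; at least one stereo element is drawn with a configuration in one of them and without one in the other: 1 of 1 stereo elements differ; a stereocentre at a saturated chain carbon is drawn without a configuration in compound 1 and R in compound 4. Only the handedness at that one carbon is in question. A compound drawn without a configuration may be a mixture of both mirror forms, although the data do not confirm this for compound 1.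

Going by the values given here, the only measured step is a 1.9-fold lower number from compound 2 to compound 3 (0.28 log units; within the scatter). It exchanges a group on nitrogen, leaves the configuration alone and stays within the scatter, so it says little about this change. Compound 2 and compound 3 are both drawn S at the matching chain carbon, and both sit higher than compound 1. They also differ from compound 1 in their other nitrogen group, so this is only a weak hint that the R form is the stronger one.

The expected change is small and downward, a 2.2-fold lower number from compound 1 to compound 4 (0.33 log units; beyond the scatter), close to the edge of the scatter. For compound 4 the estimated value is 700 nM, with an expected range from 250 nM to 1700 nM.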

Compound 4, half-maximal inhibitory concentration: 24000 nM
Estimate against measurement, compound 4: 34-fold (1.54 log units) below; measured number outside the range, above it.
By their numbers in this assay, from the lowest: compound 1; then compounds 3, 2 and 4 (each within the scatter of the next, the first and the last beyond it).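

Fixing the one chain carbon as R gives a 16-fold higher number from compound 1 to compound 4 (1.20 log units; beyond the scatter), so in this assay the handedness at this position matters a great deal, even though no atom or bond changes. For the compounds shown here, the earlier compounds could not show this, since the only step among them swaps a group on nitrogen, leaves the configuration alone and stays within the scatter. The large gap can be tied to this carbon alone, because nothing else separates the two drawings: the fact that one of compounds 1 and 4 is drawn with a defined configuration and the other without, at the place where they differ. If compound 1 is indeed a mixture of both mirror forms, the R form cannot be the main source of its inhibition, and the S form would be the likelier contributor.

On these data alone, whether compound 1 is such a mixture stays open, as does the number that the S form, with the rest of compound 4 unchanged, would give. Also open, as far as these compounds go, is whether this preference for one hand would hold with a longer chain at that stereocentre, or with a methoxy group in place of the chlorine on the shared core.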